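The source may hold more compounds than are shown below. What is called first, only, known or untested is meant among the compounds shown, and "the series" means these compounds.

Measured in a functional assay on Jurkat cells (Homo sapiens) for cytotoxicity, with a stated time of 72 h (a higher number here means that more compound is needed for the effect, a lower number that less compound is needed), read as half-maximal effective concentration:

Compound 1 `C=C[C@@](C)(/C=C/c1ccc(O)cc1)CCC1OC1(C)C`: > 49000 nM
Compound 2 `C=C[C@@](C)(/C=C/c1ccc(O)cc1)CCC=O`: > 49000 nM
Compound 3 `C=C[C@@](C)(/C=C/c1ccc(O)cc1)CC/C=C/C(=O)OCC`: > 49000 nM

Each of these entries is a limit of the assay and not a number. Compound 3 therefore stands at a limit, > 49000 nM, with no number to place it. The same holds across the set: the limit of > 49000 nM in this assay, at which 3 of the 3 values shown sit.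

Compound 4 `C=C[C@@](C)(/C=C/c1ccc(O)cc1)CC/C=C(C)/C=N/N` keeps the shared core and differs from compound 3 in one place: a group of 6 heavy atoms (4 carbon, 2 nitrogen; no ring) in place of a group of 7 heavy atoms (5 carbon, 2 oxygen; no ring), on a saturated chain carbon, three bonds along the chain from two double-bonded chain carbons. A group with no common name replaces 2-(ethoxycarbonyl)ethenyl on a saturated chain carbon, three bonds along the chain from two double-bonded chain carbons.

Among the measured compounds shown here, three measured steps concern this same place: a step that the two limits leave unreadable from compound 1 to compound 2, a step that the two limits leave unreadable from compound 1 to compound 3 and a step that the two limits leave unreadable from compound 2 to compound 3. None has a readable size, so they offer no measure for the new change. They show only that none of the three groups yielded a number in this assay. Compound 4 is therefore expected to remain near the limit, with any readable change most likely toward less compound being needed. The expected step is an at least 1.1-fold lower number from compound 3 to compound 4 (0.06 log units; that floor lies within the scatter). For compound 4 the estimated value is 42000 nM, with an expected range from 15000 nM to 60000 nM.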

Compound 4, half-maximal effective concentration: > 49000 nM
Compound 4 ended at the assay's limit; the forecaster's own chance of this, stated with the estimate: 65%; middle value at least 1.1-fold (0.06 log units) away from the limit.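

In this assay compound 4 gives > 49000 nM, which is a limit and not a number. The steps to compound 4 from compound 1, compound 2 and compound 3 cannot be read, and the whole set stands at one limit: the limit of > 49000 nM in this assay, at which 4 of the 4 values shown sit. The compounds shown leave open what number any of them would have in this assay, and whether any group at this place changes it.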